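Methoxyphenyl Replaces Pyrimidinyl in a Cytotoxicity Check

The source may report more compounds than this note shows. Statements on the series, on what has been measured and on what is new or still open speak of the compounds shown alone.

Compound 2 `N#CCCCn1c(Cn2c(=O)n(-c3ccncn3)c3ccncc32)cc2cc(Cl)ccc21` has been tested in an ADME assay on HeLa cells (Homo sapiens) for cytotoxicity, read by ATP content, with a stated time of 3 days; on this read-out lower numbers stand for higher toxicity in this test and higher numbers for lower toxicity in this test. In this assay compound 2 gives only a limit, > 50000 nM. Its close relative compound 1 `N#CCCCn1c(Cn2c(=O)n(-c3ncco3)c3ccncc32)cc2cc(Cl)ccc21` likewise reaches only a limit in this assay, namely > 50000 nM. Both results sit at the limit of > 50000 nM in this assay, at which 2 of the 2 values shown sit, so the step that the two limits leave unreadable from compound 1 to compound 2 cannot be read for size or direction. Compound 3 `COc1ccc(-n2c(=O)n(Cc3cc4cc(Cl)ccc4n3CCCC#N)c3cnccc32)cc1` differs from compound 2 by 4-methoxyphenyl in place of pyrimidin-4-yl on an aromatic nitrogen, a 4-methoxyphenyl in place of pyrimidin-4-yl on an aromatic nitrogen. Among the compounds with values here, the one measured step, a step that the two limits leave unreadable from compound 1 to compound 2, also exchanges the group on this aromatic nitrogen, yet it yields no readable size, so no change beyond the usual scatter is expected in either direction. Compound 3 is therefore expected to rest near the same limit, with an estimated 60000 nM spanning 30000 nM to 120000 nM. The expected step that the limit leaves unreadable from compound 2 to compound 3 is accordingly judged small.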

Compound 3, half-maximal cytotoxic concentration: > 50000 nM
Compound 3 was reported as a limit (the forecaster's own chance of this, stated with the estimate: 75%); the middle value does not contradict the limit.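

In this assay compound 3 gives > 50000 nM, which is a limit. No step among compound 1, compound 2 and compound 3 can be read for size or direction: the limit of > 50000 nM in this assay, at which 3 of the 3 values shown sit.

The compounds shown leave open whether exchanging the group on the aromatic nitrogen changes the half-maximal cytotoxic concentration at all.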